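The source may report more compounds than this note shows. Statements on the series, on what has been measured and on what is new or still open speak of the compounds shown alone.

Measured compounds:
- compound 1 `Cc1nc(N(C)C2CCCC2)nc2ccc(NC(=O)/C=C/c3ccc(Cl)cc3)cc12`: 399 nM
- compound 2 `C/C(=C\C(=O)Nc1ccc2nc(N3CCC(O)CC3)nc(C)c2c1)c1ccc(Cl)cc1`: 670 nM

In an assay on CHO-K1 cells for displacement of a labelled ligand from melanin-concentrating hormone receptor 1 (Homo sapiens), read by scintillation proximity assay, with a stated time of 2 h (a lower number here means a stronger inhibitor, a higher number a weaker inhibitor), compound 1 gives 399 nM and compound 2 gives 670 nM. Compound 2 has the higher of the two numbers, but its distance from compound 1 lies within the scatter of repeated measurements, so the two read as equivalent on this evidence.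

Compound 3 `C/C(=C\C(=O)Nc1ccc2nc(N3CCC(O)(C4CC4)CC3)nc(C)c2c1)c1ccc(Cl)cc1` differs from compound 2 in one place: cyclopropyl in place of hydrogen on a saturated ring carbon, taking 4-hydroxypiperidin-1-yl to 4-cyclopropyl-4-hydroxypiperidin-1-yl. Among the compounds with values here, no measured pair shows this change, so nothing here tells its size or direction. The step from compound 2 to compound 3 is expected to be small, a 1.2-fold lower number from compound 2 to compound 3 (0.09 log units; within the scatter), not clearly beyond the scatter. Compound 3 is estimated at 550 nM in this assay, in a range from 200 nM to 1500 nM.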

Compound 3, half-maximal inhibitory concentration: 532 nM
Beside the measured number, compound 3's estimate is 1.0-fold (0.01 log units) above it; measured number inside the range.
By their numbers in this assay, from the lowest: compounds 1, 3 and 2 (each within the scatter of the next).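

In this assay, cyclopropyl in place of hydrogen on a saturated ring carbon, taking 4-hydroxypiperidin-1-yl to 4-cyclopropyl-4-hydroxypiperidin-1-yl, gives a 1.3-fold lower number from compound 2 to compound 3 (0.10 log units; within the scatter) and leaves the pair equivalent on this evidence. Within the data shown here, this is the only pair that differs in one place, and it shows that this ring carbon, three ring bonds from the ring nitrogen, can carry cyclopropyl with no step beyond the scatter. No measured property of either group is available to account for this result.

A single group at a single position cannot show whether phenyl, a longer alkyl chain, an amine or a carboxylic acid on this carbon would also stay within the scatter. It also leaves open what happens when the hydroxyl on this carbon is replaced by a methoxy group or a fluorine atom.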